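Oxime series: cytotoxicity and a bromo-for-chloro exchange

The compounds below may be only part of what the source reports. "The series", "measured", "known", "first", "only" and "open" are said of these compounds alone.

Measured so far:
- Compound 1 `COc1ccc(C(/C=C/c2ccc(Cl)cc2)=N/O)cc1`: in an ADME assay on cells (Mus musculus, strain Balb/c) for cytotoxicity, read by MTT assay, with a stated time of 48 h (a higher number here means that more compound is tolerated, a lower number that less compound is tolerated), compound 1 gives 291000 nM.
- Compound 2 `O/N=C(\C=C\c1ccc(Cl)cc1)c1ccc(Cl)cc1`: in this assay compound 2 gives 14100 nM.

Compound 2 holds the lower of the two numbers seen so far, and the gap to compound 1 is wide: a 21-fold lower number from compound 1 to compound 2 (1.31 log units; beyond the scatter). That single step is the only one measured, and the exchange it covers is the one named with it.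

The next compound, compound 3 `O/N=C(\C=C\c1ccc(Cl)cc1)c1ccc(Br)cc1`, differs from compound 2 in one place: bromo in place of chloro on an aromatic carbon. Within the data shown here, the measured step bears on this only loosely, since it describes a different exchange at that aromatic carbon; there is no measured pair in which bromo replaces chloro. With chloro already in place on compound 2, a move to bromo is expected to shift the number little in this assay, if at all beyond the scatter, with a slight lean toward a lower number.

The expected step from compound 2 to compound 3 is therefore a 1.4-fold lower number from compound 2 to compound 3 (0.15 log units; within the scatter). Compound 3 is expected to give 10000 nM in this assay, within a range of 3500 nM to 30000 nM.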

Compound 3, half-maximal cytotoxic concentration: 24700 nM
Estimate against measurement, compound 3: 2.5-fold (0.39 log units) below, within the range that was stated.
By their numbers in this assay, from the lowest: compounds 2 and 3 (each within the scatter of the next); then compound 1.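

Working notes: in this assay, the first measured pair for this exchange gives a 1.8-fold higher number from compound 2 to compound 3 (0.24 log units; within the scatter), so bromo and chloro cannot be told apart at this aromatic carbon. Bromo in place of methoxy at the same carbon gives a 12-fold lower number from compound 1 to compound 3 (1.07 log units; beyond the scatter), a large step of the same direction as the one already seen with chloro, so among the three groups shown, the line falls between methoxy on one side and the two halogens on the other, with no compound going against it. No supporting measurement bears on why the steps at this carbon take the sizes they do.

What the series leaves open is how other groups at this carbon would sit relative to methoxy and the two halogens, for example fluoro, an amine, a nitrile or a carboxylic acid, since three groups give only two clusters and no trend. From the compounds shown here alone, the chloro on the other side of the shared core stays the same in all three compounds, so whether exchanging it for bromo or methoxy would give steps of a similar size also remains open.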